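A few compounds are considered here, and "the series" means these few. Any claim that something is new, unique, unknown or untested is made for them only; others in the source may bear on it.

In a functional assay on NCI-H460 cells (Homo sapiens) for antiproliferative activity, with a stated time of 72 h (a higher number here means a weaker inhibitor, a lower number a stronger inhibitor), two compounds built on a shared core have been measured. Compound 1 `CCCCC#Cc1cc([C@@H]2O[C@H](CO)[C@@H](O)[C@H]2O)n2ncnc(N)c12` gives 1700 nM, while compound 2 `Nc1ncnn2c([C@@H]3O[C@H](CO)[C@@H](O)[C@H]3O)cc(-c3ccc(F)cc3)c12` gives 55500 nM, the higher of the two numbers, which makes it the weaker inhibitor of the pair. Going by the values given here, the one measured step is a 33-fold higher number from compound 1 to compound 2 (1.51 log units; beyond the scatter). It is large, lies beyond the scatter and comes with 4-fluorophenyl in place of hex-1-yn-1-yl on an aromatic carbon.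

Compound 3 `Nc1ncnn2c([C@@H]3O[C@H](CO)[C@@H](O)[C@H]3O)cc(/C=C/c3ccccc3)c12` replaces that same 4-fluorophenyl group: 2-phenylethenyl in place of 4-fluorophenyl on an aromatic carbon. Here, 2-phenylethenyl stands in place of 4-fluorophenyl on an aromatic carbon. Among the compounds with values here, no measured compound carries 2-phenylethenyl, so the evidence is thin. Within the data shown here, the only guide is the step of a 33-fold higher number from compound 1 to compound 2 (1.51 log units; beyond the scatter), which shows that this group can move the number by a wide margin. A moderate move toward a lower number is therefore expected in this assay, smaller than that measured step. The expected change is a 3.7-fold lower number from compound 2 to compound 3 (0.57 log units; beyond the scatter). The estimate for compound 3 is 15000 nM, with an expected range from 3000 nM to 55000 nM.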

Compound 3, half-maximal inhibitory concentration: 3700 nM
Beside the measured number, compound 3's estimate is 4.1-fold (0.61 log units) above it; the range from low to high includes it.
By their numbers in this assay, from the lowest: compound 1; then compound 3; then compound 2.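

At this aromatic carbon, two ring bonds from the ring nitrogen, carrying a six-membered aromatic ring of carbon only does not settle the number: in this assay, 2-phenylethenyl in place of 4-fluorophenyl gives a 15-fold lower number from compound 2 to compound 3 (1.18 log units; beyond the scatter), although both groups hold that same ring. Set against the hexynyl group, the aromatic ring need not carry a large penalty at this position, for 2-phenylethenyl in place of hex-1-yn-1-yl gives only a 2.2-fold higher number from compound 1 to compound 3 (0.34 log units; beyond the scatter), a modest step that still leaves compound 1 the strongest inhibitor of the three. Nothing in the information at hand accounts for either step. The compounds shown leave open how a plain phenyl or a saturated 2-phenylethyl group would read at this carbon, and so whether the change follows the double bond outside the aromatic rings, the loss of fluorine or the extra carbon atoms. Also open, from the compounds shown here alone, is how far a shorter alkyne such as prop-1-yn-1-yl, or a hexynyl chain ending in an amine, would stay close to compound 1.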